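This account rests on a few compounds, and the source may have more. Where it says the series, first, only, none or still open, it means among the compounds named here.

Compound 1 `NC1=NC2(CCSCC2)N(OCCCOc2cccc(Cl)c2Cl)C(N)=N1`: 50 nM
Compound 2 `NC1=NC2(CCOCC2)N(OCCCOc2cccc(Br)c2)C(N)=N1`: 320 nM
Compound 3 `Cc1ccc(OCCCON2C(N)=NC(N)=NC23CCOCC3)cc1`: "not determined" (no result reported)

In a functional assay on HepG2 cells (Homo sapiens) for antiproliferative activity, read by MTT assay, with a stated time of 72 h (a higher number here means a weaker inhibitor, a lower number a stronger inhibitor), compound 1 stands lowest of the two numbers available, at 50 nM. Compound 2 gives 320 nM, and that gap lies beyond the scatter. For compound 3 the entry reads "not determined" (no result reported), so it offers no number to compare.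

The next compound is compound 4 `NC1=NC2(CCSCC2)N(OCCCOc2ccc(Cl)cc2)C(N)=N1`. Relative to compound 1, it carries this change: 4-chlorophenyl in place of 2,3-dichlorophenyl on an oxygen on a saturated carbon. In words, it has 4-chlorophenyl in place of 2,3-dichlorophenyl on an oxygen on a saturated carbon, and the rest of the structure is unchanged.

Within the data shown here, no pair of measured compounds isolates this change, so the expectation is loose. A moderate move toward a higher number in this assay is expected, with compound 2 at 320 nM as the only other measured reference. The expected size of the move is a 3.0-fold higher number from compound 1 to compound 4 (0.48 log units; beyond the scatter). For compound 4 the estimated value is 150 nM, with an expected range of 40 nM to 500 nM.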

Compound 4, half-maximal inhibitory concentration: 1100 nM
For compound 4 the middle estimate is 7.3-fold (0.87 log units) below the measured one; measured number above the stated range.
By their numbers in this assay, from the lowest: compound 1; then compound 2; then compound 4.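

With the shared core and chain unchanged, putting 4-chlorophenyl in place of 2,3-dichlorophenyl on an oxygen on a saturated carbon gives a 22-fold higher number from compound 1 to compound 4 (1.34 log units; beyond the scatter) in this assay. This is the only single-place comparison shown, and its large size shows that the reading is highly sensitive to the aryl group at this position. The change both removes a chlorine and alters the chlorine pattern, so the pair cannot separate these two differences, and nothing measured here accounts for the step.

The compounds shown leave open how an unsubstituted phenyl, a 3-chlorophenyl or a pyridine ring would read at this place. They also leave open whether a step of similar size would appear on the core of compound 2.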